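Ethoxy for 4-chlorophenyl on the carbonyl: cytotoxicity notes

A few compounds are considered here, and "the series" means these few. Any claim that something is new, unique, unknown or untested is made for them only; others in the source may bear on it.

Of the compounds shown here, two sharing one core have been read in a functional assay on MT4 cells (Homo sapiens) for cytotoxicity; on this read-out higher numbers stand for lower toxicity in this test and lower numbers for higher toxicity in this test. Compound 1 (`CC(=O)CSc1nc(O)c(C(C)C)c(Cc2cccc3ccccc23)n1`) gives 43000 nM. Compound 2 (`CC(C)c1c(O)nc(SCC(=O)c2ccc(Cl)cc2)nc1Cc1cccc2ccccc12`) gives > 270000 nM, which is a limit of the assay and not a number. Compound 2 therefore stands on (the limit of > 270000 nM in this assay, at which 1 of the 2 values shown sits).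

Compound 3 (`CCOC(=O)CSc1nc(O)c(C(C)C)c(Cc2cccc3ccccc23)n1`) carries ethoxy in place of 4-chlorophenyl on a carbonyl carbon. For the measured compounds named here, the only measured step bearing on this change is an at least 6.2-fold higher number from compound 1 to compound 2 (0.79 log units; beyond the scatter), where 4-chlorophenyl took the place of methyl on a carbonyl carbon. The change to compound 3 removes the same 4-chlorophenyl, and the entering ethoxy, like the methyl of compound 1, has no ring. A step of similar size but in the opposite direction, towards a lower number in this assay, is therefore expected, with the value of compound 1 as the nearest guide. The expected size is an at least 4.5-fold lower number from compound 2 to compound 3 (0.65 log units; beyond the scatter). For compound 3 the estimated value is 60000 nM, with an expected range of 20000 nM to 200000 nM.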

Compound 3, half-maximal cytotoxic concentration: 175000 nM
Compound 3: the middle estimate sits 2.9-fold (0.46 log units) below what was measured; the range from low to high includes it.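

On the carbonyl carbon, a group with no ring can also shift the read-out in this assay: ethoxy in place of methyl gives a 4.1-fold higher number from compound 1 to compound 3 (0.61 log units; beyond the scatter). The earlier pair showed a rise only with 4-chlorophenyl, so that ring is not the only route to a higher number on this carbonyl carbon. Ethoxy in place of 4-chlorophenyl gives an at least 1.5-fold lower number from compound 2 to compound 3 (0.18 log units; that floor lies within the scatter), and the reading for compound 2 is a limit of the assay, not a number, which leaves the true size of this step unknown and prevents any firm ranking of the two groups because of it: the limit of > 270000 nM in this assay, at which 1 of the 3 values shown sits.

As far as these compounds go, it remains open whether a carboxylic acid, an amine or a longer chain on the same carbonyl carbon would stay near compound 3 or fall back towards compound 1. From the compounds shown here alone, it is also open whether the rise from methyl to ethoxy follows the chain or the oxygen that enters with it, which a plain ethyl group on the carbonyl carbon would help to separate.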